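This account rests on a few compounds, and the source may have more. Where it says the series, first, only, none or still open, it means among the compounds named here.

Compound 1 `Cc1ccc(N2C(=O)C=CC2OCC(F)(F)F)cc1`: 13700 nM
Compound 2 `CCc1ccc(N2C(=O)C=CC2OCC(F)(F)F)cc1`: 8090 nM
Compound 3 `O=C1C=CC(OCC(F)(F)F)N1c1ccccc1`: 23400 nM

All three compounds share one core and differ only on the aromatic ring attached to it. In a functional assay on A549 cells (Homo sapiens) for inhibition (a lower number here means a stronger inhibitor, a higher number a weaker inhibitor), compound 3 gives 23400 nM, the highest of the three numbers. Its nearest neighbour is compound 1, with a 1.7-fold higher number from compound 1 to compound 3 (0.23 log units; within the scatter), and its furthest is compound 2, with a 2.9-fold higher number from compound 2 to compound 3 (0.46 log units; beyond the scatter). Between the two substituted compounds the difference is a 1.7-fold lower number from compound 1 to compound 2 (0.23 log units; within the scatter).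

Compound 4 `O=C1C=CC(OCC(F)(F)F)N1c1ccccc1F` is the next step from compound 3: fluoro in place of hydrogen on an aromatic carbon, on an aromatic carbon of a six-membered aromatic ring of carbon only, ortho to a large group. The measured steps that bear on it are those on the same aromatic ring, a 1.7-fold higher number from compound 1 to compound 3 (0.23 log units; within the scatter) and a 2.9-fold higher number from compound 2 to compound 3 (0.46 log units; beyond the scatter), which show that an added group on that ring lowers the number at most modestly. None of them involves fluoro, and none sits at the same place on the ring, so they carry only loosely. The expected step in this assay is therefore small, at most a slight lowering and most likely within the scatter; the estimated step is a 1.2-fold lower number from compound 3 to compound 4 (0.07 log units; within the scatter). In this assay compound 4 is expected to give about 20000 nM, with a range from 8000 nM to 50000 nM.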

Compound 4, half-maximal inhibitory concentration: 44900 nM
Estimate against measurement, compound 4: 2.2-fold (0.35 log units) below, within the range that was stated.
By their numbers in this assay, from the lowest: compounds 2, 1, 3 and 4 (each within the scatter of the next, the first and the last beyond it).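

In this assay fluoro in place of hydrogen, on an aromatic carbon ortho to a large group, gives a 1.9-fold higher number from compound 3 to compound 4 (0.28 log units; within the scatter), so at this place on the ring the change stays within the scatter. For the compounds shown here, the earlier steps on this ring concerned only methyl and ethyl at another place, and only the ethyl step lay beyond the scatter, towards a lower number; this step is the only reading for fluoro and the only one for a group ortho to a large group, and it gives no sign of that lowering. No measurement at hand accounts for this result.

Whether the number at this place depends on the group that enters stays open, as fluoro is the only group shown there, and a methyl, a chloro or a methoxy group at the same place could give a different step. Equally open, on these data alone, is whether fluoro at the place held by methyl in compound 1 and by ethyl in compound 2 would match those groups, and whether an amine or a carboxylic acid on the ring would move the number beyond the scatter.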